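Adding a methoxy group to the aromatic ring of compound 3

A few compounds are considered here, and "the series" means these few. Any claim that something is new, unique, unknown or untested is made for them only; others in the source may bear on it.

Of the compounds shown here, three sharing one core have been tested in a toxicity assay on the whole organism (strain Icem-CET (SPF Caw)) for cytotoxicity, with Mus musculus as the target; on this read-out higher numbers stand for an effect only at larger amounts of compound and lower numbers for an effect already at smaller amounts. Compound 1 `C/C(C(=O)NC1CC1)=C(/C)c1ccc(Br)cc1` gives 100 mg/kg. Compound 2 `C=CCNC(=O)/C(C)=C(\C)c1ccc(OC)cc1` gives 200 mg/kg. Compound 3 `C/C(C(=O)NC1CC1)=C(/C)c1ccccc1` gives 100 mg/kg. On these numbers compound 3 stands level with compound 1, and the two together hold the lowest value of the three; compound 2 lies a modest way above, but that gap stays within the usual scatter, so no real order can be read from it.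

The next compound, compound 4 `COc1ccc(/C(C)=C(\C)C(=O)NC2CC2)cc1`, differs from compound 3 in one place: methoxy in place of hydrogen on an aromatic carbon.

Going by the values given here, only one measured step touches the same aromatic ring, and it shows that swapping one ring substituent for another leaves the read-out essentially where it was: no change at the digits printed from compound 1 to compound 3 (within the scatter). Compound 2 also carries a methoxy group, but it differs from compound 3 in a second place as well, so its value alone cannot be tied to the methoxy group. Taken together, the expectation is no change beyond the scatter, leaning at most slightly toward a higher number, which is what the estimate a 1.4-fold higher number from compound 3 to compound 4 (0.15 log units; within the scatter) expresses. Compound 4 is therefore expected to give about 140 mg/kg in this assay, most likely between 70 mg/kg and 280 mg/kg.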

Compound 4, dose for half-maximal effect: 250 mg/kg
Beside the measured number, compound 4's estimate is 1.8-fold (0.25 log units) below it; measured number inside the range.
By their numbers in this assay, from the lowest: compounds 1, 3, 2 and 4 (each within the scatter of the next, the first and the last beyond it).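

At this position, an aromatic carbon para to a large group, the choice of substituent does matter in this assay: methoxy in place of hydrogen gives a 2.5-fold higher number from compound 3 to compound 4 (0.40 log units; beyond the scatter), and methoxy in place of bromo gives a 2.5-fold higher number from compound 1 to compound 4 (0.40 log units; beyond the scatter). Since a higher number here means the effect appears only at a larger dose, methoxy moves the read-out in a way the swap of bromo for hydrogen did not, although both steps are modest and rest on a single pair each. With methoxy kept on the ring, the other end of the molecule shows no such shift: cyclopropyl in place of allyl on the amide nitrogen gives a 1.3-fold higher number from compound 2 to compound 4 (0.10 log units; within the scatter).

No measurement among these compounds bears on what lies behind the methoxy step. The compounds shown leave open whether a hydroxyl group, an ethoxy group or an amine on the same carbon would shift the number as methoxy does, and whether methoxy in place of hydrogen gives the same step when allyl sits on the amide nitrogen.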